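Bromo to chloro exchange on two cores

The source may report more compounds than this note shows. Statements on the series, on what has been measured and on what is new or still open speak of the compounds shown alone.

Measured so far in a functional assay on T47D cells (Homo sapiens) for inhibition, with a stated time of 48 h, at 37 degrees C; a lower number here means a stronger inhibitor of growth, a higher number a weaker inhibitor of growth:
compound 1, `Clc1ccc(-c2noc(-c3occc3Br)n2)cc1`: 120 nM
compound 2, `Clc1ccc(-c2noc(-c3occc3Cl)n2)cc1`: 120 nM
compound 3, `Clc1ccc(-c2noc(-c3occc3Br)n2)nc1`: 380 nM

Compound 1 and compound 2 share a core and differ only by chloro in place of bromo on an aromatic carbon. That step reads no change at the digits printed from compound 1 to compound 2 (within the scatter). Compound 3 carries the bromo group of compound 1 on a different core; the difference between the two cores is not broken down here. In this assay compound 3 gives 380 nM, whereas compound 1 gives 120 nM, so compound 3 is the weakest of the three measured compounds.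

Compound 4, `Clc1ccc(-c2noc(-c3occc3Cl)n2)nc1`, is not yet measured. It differs from compound 3 by chloro in place of bromo on an aromatic carbon, the same change as from compound 1 to compound 2, at the same place. Within the data shown here, the only precedent is no change at the digits printed from compound 1 to compound 2 (within the scatter) on the core of compound 1, and nothing in the measured compounds suggests a different outcome on the core of compound 3. The step from compound 3 to compound 4 is therefore expected to be no change at the digits printed from compound 3 to compound 4 (within the scatter), resting on no change at the digits printed from compound 1 to compound 2 (within the scatter). Compound 4 is expected to give about 380 nM in this assay, with 200 nM to 750 nM as the likely range.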

Compound 4, concentration for 50% growth inhibition: 13000 nM
Beside the measured number, compound 4's estimate is 34-fold (1.53 log units) below it, and the stated range ends below it.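

In this assay, replacing 3-bromofuran-2-yl with 3-chlorofuran-2-yl on the core of compound 3 gives a 34-fold higher number from compound 3 to compound 4 (1.53 log units; beyond the scatter) and marks a large loss of growth inhibition. This does not show which difference between the two cores goes with the split, nor whether it would hold for other pairs, as each core contributes only one bromo and chloro pair. What it does show is that, in this series, the result of this exchange on the core of compound 1 cannot be carried over to the core of compound 3, and the two steps differ: the same change on two cores in this assay, no change at the digits printed (within the scatter) from compound 1 to compound 2 and a 34-fold higher number (1.53 log units; beyond the scatter) from compound 3 to compound 4, 34-fold (1.53 log units) apart, beyond the scatter of two such steps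

Going by these compounds, whether a methyl, an amine or a nitrile on that aromatic carbon would follow the step on the core of compound 1 or the one on the core of compound 3 remains open. Also open, on these data alone, is how the two cores would compare with a group other than chloro or bromo at this place.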